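Swapping a methoxyphenyl for a fluorophenyl on a urea

The source may hold more compounds than are shown below. What is called first, only, known or untested is meant among the compounds shown, and "the series" means these compounds.

The compounds here share a core built around a urea carrying a trimethoxyphenyl group, and they were tested in a functional assay on Daoy cells (Homo sapiens) for cytotoxicity, read by MTT assay, with a stated time of 72 h; on this read-out higher numbers stand for weaker inhibition and lower numbers for stronger inhibition. Compound 1, with structure `COc1ccc(N(C)C(=O)N(C)c2cc(OC)c(OC)c(OC)c2)cc1`, gives in this assay only a limit of the assay and no exact number, >= 125000 nM. Compound 3, with structure `COc1cc(NC(=O)Nc2cccc3cc(O)ccc23)cc(OC)c1OC`, likewise gives only a limit in this assay, >= 125000 nM. Compound 2, with structure `COc1cc(NC(=O)Nc2ccccc2)cc(OC)c1OC`, has no result in this assay at all, "not determined" (no result reported). So compound 1 stands at the limit shared with compound 3, because of the limit of >= 125000 nM in this assay, at which 2 of the 3 values shown sit, and nothing among the measured compounds shows a single exact number.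

Compound 4, with structure `COc1cc(N(C)C(=O)N(C)c2cccc(F)c2)cc(OC)c1OC`, differs from compound 1 by one change: 3-fluorophenyl in place of 4-methoxyphenyl on an amide-type nitrogen. Within the data shown here, no measured pair follows this change, so no step size can be read from the data. Given that compound 1 sits at the limit >= 125000 nM, the expected step from compound 1 to compound 4 in this assay is a number no higher from compound 1 to compound 4 (the limit leaves the size open), that is, none beyond the scatter. Compound 4 is therefore expected to give about 125000 nM, within a range from 40000 nM to 300000 nM.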

Compound 4, half-maximal inhibitory concentration: >= 125000 nM
Compound 4 gave a limit, no number; the forecaster's own chance of this, stated with the estimate: 75%; the middle value lies on the limit itself.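

Compound 1 and compound 4 both end at a limit of this assay and not at an exact number, so no step can be read between them: the limit of >= 125000 nM in this assay, at which 3 of the 4 values shown sit.

The compounds shown leave open whether 3-fluorophenyl in place of 4-methoxyphenyl on an amide-type nitrogen changes cytotoxicity at all, and none of them gives an exact number to compare against.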